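The source may hold more compounds than are shown below. What is called first, only, known or untested is meant among the compounds shown, and "the series" means these compounds.

Working notes on the series, read in an ADME assay on the whole organism (Macaca fascicularis) for pharmacokinetics, with stated times of 24 h and 72 h, at a dose of 1 mg/kg by the oral route; on this read-out lower numbers stand for lower exposure and higher numbers for higher exposure at the dose given. Among the measured compounds shown here, compound 1 `Cc1ncncc1-c1nc2cc(F)c(F)cc2n1C1CC1` gives 859 ng.h/mL, and compound 2 `Fc1cc2nc(-c3cncnc3C(F)F)n(C3CC3)c2cc1F` gives 2840 ng.h/mL, the highest of the two numbers so far. Compound 3 `Fc1cc2nc(-c3cncnc3C(F)(F)F)n(C3CC3)c2cc1F` differs from compound 2 by fluoro in place of hydrogen on a saturated chain carbon bound to an aromatic carbon and two fluorine atoms, which reads as difluoromethyl to trifluoromethyl. For the measured compounds named here, the only measured step bearing on this is a 3.3-fold higher number from compound 1 to compound 2 (0.52 log units; beyond the scatter), a modest one, with difluoromethyl in place of methyl. A further rise in the same direction is possible, but a smaller one is expected, probably none beyond the scatter. The estimated step is a 1.1-fold higher number from compound 2 to compound 3 (0.05 log units; within the scatter). Compound 3 is expected at 3200 ng.h/mL, with an estimated range of 1300 ng.h/mL to 8000 ng.h/mL.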

Compound 3, area under the concentration-time curve: 2650 ng.h/mL
For compound 3 the middle estimate is 1.2-fold (0.08 log units) above the measured one, within the range that was stated.
By their numbers in this assay, from the lowest: compound 1; then compounds 3 and 2 (each within the scatter of the next).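

In this assay the change from difluoromethyl to trifluoromethyl gives a 1.1-fold lower number from compound 2 to compound 3 (0.03 log units; within the scatter) and does not separate the two groups. The change from methyl to trifluoromethyl gives a 3.1-fold higher number from compound 1 to compound 3 (0.49 log units; beyond the scatter) and so matches the gain already seen with difluoromethyl, which means that this position tolerates the third fluorine without a loss beyond the scatter. No measurement at hand accounts for either step. As far as these compounds go, whether ethyl, methoxy or an amine in place of methyl on that aromatic carbon would keep this exposure stays open.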